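The source may report more compounds than this note shows. Statements on the series, on what has been measured and on what is new or still open speak of the compounds shown alone.

Measured so far in an assay on isolated protein for inhibition of Polyunsaturated fatty acid 5-lipoxygenase (Homo sapiens); on this read-out higher numbers stand for weaker inhibition and lower numbers for stronger inhibition: compound 1 `NC(=O)N(O)CCC#Cc1ccc(OCCCCN2CCN(C(c3ccc(F)cc3)c3ccc(F)cc3)CC2)cc1` gives 193 nM; compound 2 `CCOC(=O)N(O)CCC#Cc1ccc(OCCCCN2CCN(C(c3ccc(F)cc3)c3ccc(F)cc3)CC2)cc1` gives 365 nM.

Among the measured compounds shown here, compound 2 stands highest of the two numbers, with compound 1 as its only neighbour; the step of a 1.9-fold higher number from compound 1 to compound 2 (0.28 log units; within the scatter) lies within the scatter. Compound 3 `O=C(OCc1ccccc1)N(O)CCC#Cc1ccc(OCCCCN2CCN(C(c3ccc(F)cc3)c3ccc(F)cc3)CC2)cc1` carries phenyl in place of methyl on a saturated chain carbon bound to an oxygen next to a carbonyl group, that is ethoxycarbonyl to benzyloxycarbonyl. For the measured compounds named here, no measured step bears on this change directly, and the single step known, amino to ethoxy on the carbonyl carbon, stayed within the scatter. Compound 3 is therefore expected to show no step beyond the scatter in this assay, if anything a slightly higher number, a 1.2-fold higher number from compound 2 to compound 3 (0.09 log units; within the scatter). Compound 3 is estimated at 450 nM, range 150 nM to 1400 nM.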

Compound 3, half-maximal inhibitory concentration: 350 nM
For compound 3 the middle estimate is 1.3-fold (0.11 log units) above the measured one; measured number inside the range.
By their numbers in this assay, from the lowest: compounds 1, 3 and 2 (each within the scatter of the next).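

In this assay, phenyl in place of methyl on a saturated chain carbon bound to an oxygen next to a carbonyl group gives a 1.0-fold lower number from compound 2 to compound 3 (0.02 log units; within the scatter) and so adds a six-membered aromatic ring with no step beyond the scatter. The comparison with the amino group gives a 1.8-fold higher number from compound 1 to compound 3 (0.26 log units; within the scatter) and so leaves amino, ethoxy and benzyloxy unseparated at this position. Nothing on hand offers a reason for this result.

Open, as far as these compounds go, is whether any other group on this carbonyl carbon, such as dimethylamino or tert-butoxy, would give a step beyond the scatter.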